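Allyl-bearing bis-arylidene cores: swapping the halogenated aryl ring

The source may hold more compounds than are shown below. What is called first, only, known or untested is meant among the compounds shown, and "the series" means these compounds.

Measured compounds:
- compound 1, `COc1ccccc1/C=c1\c(=O)[nH]/c(=C/c2cccc(Cl)c2Cl)c(=O)n1C`: 200 nM
- compound 2, `C=CCn1c(=O)/c(=C\c2cc(F)ccc2C)[nH]c(=O)/c1=C\c1ccccc1OC`: 2900 nM

Of the compounds shown here, two have been tested in a functional assay on HeLa cells (Homo sapiens) for cytotoxicity, read by CCK-8 assay, with a stated time of 72 h; on this read-out higher numbers stand for weaker inhibition and lower numbers for stronger inhibition. Compound 1 gives 200 nM in this assay, while compound 2 gives 2900 nM, which is the higher of the two numbers and lies clearly beyond the scatter of repeated measurements. Going by the values given here, the two compounds differ in more than one place, so no single structural step can be drawn between them; their values show only that compound 2 is the weaker of the pair.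

Compound 3, `C=CCn1c(=O)/c(=C\c2cccc(Cl)c2)[nH]c(=O)/c1=C\c1ccccc1OC`, has not been measured. It differs from compound 2 in one place: 3-chlorophenyl in place of 5-fluoro-2-methylphenyl on a double-bonded chain carbon bound to an aromatic carbon. Compound 3 thereby shares its allyl group and its 2-methoxyphenyl group with compound 2, while its chlorine-bearing ring brings it closer to compound 1.

Because compound 1 gives 200 nM with a chlorine-bearing ring at the same position, an improvement is expected, estimated as a 3.2-fold lower number from compound 2 to compound 3 (0.51 log units; beyond the scatter), a moderate step downward. For compound 3 the expected value in this assay is 900 nM, with a range from 300 nM to 2700 nM.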

Compound 3, half-maximal inhibitory concentration: 5500 nM
Estimate against measurement, compound 3: 6.1-fold (0.79 log units) below, outside the stated range (above it).
By their numbers in this assay, from the lowest: compound 1; then compounds 2 and 3 (each within the scatter of the next).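

In this assay, going by these compounds alone, the exchange of 5-fluoro-2-methylphenyl for 3-chlorophenyl on a double-bonded chain carbon bound to an aromatic carbon gives a 1.9-fold higher number from compound 2 to compound 3 (0.28 log units; within the scatter) and so provides the first single-place step. With the allyl and 2-methoxyphenyl groups held constant, these two aryl groups cannot be told apart at this position, and a single chlorine on the ring does not by itself reproduce the low number of compound 1, which also differs from compound 3 in a second place. Nothing available here explains why the two aryl groups read alike.

Within the data shown here, what separates compound 1 from the two allyl-bearing compounds remains unassigned, since no single-place step connects it to either of them. From the compounds shown here alone, it also remains open whether an aryl group carrying an amine or a carboxylic acid at this position, or a longer chain in place of the allyl group, would shift the number beyond the scatter.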